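The source may report more compounds than this note shows. Statements on the series, on what has been measured and on what is new or still open speak of the compounds shown alone.

Compound 1 `Cn1c(=O)[nH]c2c(cnn2-c2ccc(Br)cc2)c1=N`: 34%
Compound 2 `Cn1c(=O)[nH]c2c(cnn2-c2ccc(N)cc2)c1=N`: 0%
Compound 3 `Cn1c(=O)[nH]c2c(cnn2-c2ccc([N+](=O)[O-])cc2)c1=N`: 5%

The three compounds share one core and differ only in the group carried on an aromatic carbon of a six-membered aromatic ring of carbon only. In an assay on membranes from brain for binding affinity to adenosine receptor A1 (Rattus norvegicus), read by radioligand binding, tested at 20 uM (a higher number here means more inhibition at the concentration tested (going by the name of the read-out), a lower number less inhibition), compound 1 gives 34%, compound 2 gives 0% and compound 3 gives 5%. Compound 3 stands second highest of the three numbers; its number and that of compound 2 lie within the scatter of each other, as a number 5 percentage points higher from compound 2 to compound 3 (within the scatter) shows, whereas the gap to compound 1 is real, as a number 29 percentage points lower from compound 1 to compound 3 (beyond the scatter) shows.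

Compound 4 `Cn1c(=O)[nH]c2c(cnn2-c2ccc(F)cc2)c1=N` is the next step: fluoro in place of nitro on an aromatic carbon. For the measured compounds named here, two measured steps bear on it. Replacing bromo on compound 1 cost activity in both directions tried: a number 34 percentage points lower from compound 1 to compound 2 (beyond the scatter) and a number 29 percentage points lower from compound 1 to compound 3 (beyond the scatter). Fluoro, like bromo, is a halogen, so compound 1 is the nearest measured guide, but no measured step tells how a halogen other than bromo behaves at this place. A rise from compound 3 is therefore expected, though a modest one, and it may not clear the scatter. Compound 4 is expected to give about 15% in this assay, between 0% and 35%. This estimate amounts to an expected step of a number 10 percentage points higher from compound 3 to compound 4 (within the scatter).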

Compound 4, a percentage reported as inhibition, at one concentration (the size of the read-out at that concentration, not a potency): 26%
Beside the measured number, compound 4's estimate is 11 percentage points below it; low and high end bracket the measured number.
By their numbers in this assay, from the lowest: compounds 2 and 3 (each within the scatter of the next); then compounds 4 and 1 (each within the scatter of the next).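

Fluoro separates from both nitro and amino in this assay, with a number 21 percentage points higher from compound 3 to compound 4 (beyond the scatter) and a number 26 percentage points higher from compound 2 to compound 4 (beyond the scatter), yet it stays level with bromo, as a number 8 percentage points lower from compound 1 to compound 4 (within the scatter) shows. The earlier compounds shown here left open whether the standing of compound 1 over compound 2 and compound 3 was peculiar to bromo; among the four compounds, the two halogens now fall together on one side and nitro and amino on the other, with no compound going against that split. Nothing measured here explains why the groups divide this way.

What the compounds shown leave open is whether the split extends to the other halogens, chloro and iodo, or to groups that are neither halogen nor nitrogen-based, such as methyl, methoxy, hydroxyl or a carboxylic acid, and how the unsubstituted ring, with plain hydrogen at this place, would compare. Since each compound is read at a single concentration, they also leave open how the halogen-bearing compounds compare in potency, and whether a change elsewhere on the shared core would keep this same split.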